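The source may report more compounds than this note shows. Statements on the series, on what has been measured and on what is new or still open speak of the compounds shown alone.

Measured in a functional assay on OVCAR-5 cells (Homo sapiens) for inhibition, read by CCK-8 assay, with a stated time of 72 h, tested at 10 uM; on this read-out lower numbers stand for less inhibition of growth and higher numbers for more inhibition of growth at the one concentration tested:
- compound 1 `CN(C)C(=O)c1cc2cnc(Nc3ccc(NC(=O)C4(C(=O)Nc5ccccc5F)CC4)cc3)nc2n1C1CCCC1`: 82.6%
- compound 2 `CN(C)C(=O)c1cc2cnc(Nc3ccc(NC(=O)C4(C(=O)Nc5ccc(Br)cc5)CC4)cc3)nc2n1C1CCCC1`: 87.8%
- compound 3 `CN(C)C(=O)c1cc2cnc(Nc3ccc(NC(=O)C4(C(=O)Nc5cccc(Br)c5)CC4)cc3)nc2n1C1CCCC1`: 89.6%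

Compound 3 gives 89.6%, a value not separated from the other two by more than the scatter. Compound 4 `CN(C)C(=O)c1cc2cnc(Nc3ccc(NC(=O)C4(C(=O)Nc5ccccc5)CC4)cc3)nc2n1C1CCCC1` carries hydrogen in place of bromo on an aromatic carbon. Three measured steps swap the phenyl substituents on the same amide-type nitrogen: a number 5.2 percentage points higher from compound 1 to compound 2 (within the scatter), a number 7 percentage points higher from compound 1 to compound 3 (within the scatter) and a number 1.8 percentage points higher from compound 2 to compound 3 (within the scatter). None of them replaces bromo with hydrogen, so they bear on the change only indirectly. As all three stay small, no change beyond the scatter is expected in this assay. The expected step is a number 5.6 percentage points lower from compound 3 to compound 4 (within the scatter). For compound 4 the estimated value is 84%, with an expected range of 74% to 93%.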

Compound 4, percent growth inhibition at one concentration: 77.1%
Compound 4: middle estimate off by 6.9 percentage points, on the high side, and the stated range covers the measured number.
By their numbers in this assay, from the lowest: compounds 4, 1, 2 and 3 (each within the scatter of the next, the first and the last beyond it).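

In this assay, bromo on the phenyl proves to matter, which the swaps among substituted phenyls could not show: hydrogen in its place gives steps beyond the scatter from both the 3-bromophenyl (a number 12.5 percentage points lower from compound 3 to compound 4 (beyond the scatter)) and the 4-bromophenyl compound (a number 10.7 percentage points lower from compound 2 to compound 4 (beyond the scatter)). Hydrogen in place of fluoro, by contrast, stays within the scatter (a number 5.5 percentage points lower from compound 1 to compound 4 (within the scatter)). Nothing available explains the loss on removing bromo.

As far as these compounds go, whether a methoxy group, an amine or a carboxylic acid on this phenyl would hold growth inhibition near the bromo compounds remains open. Readings at one concentration also leave potency undefined.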